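The source may report more compounds than this note shows. Statements on the series, on what has been measured and on what is new or still open speak of the compounds shown alone.

Compound 1 `Cc1ccc(S(=O)(=O)N2CC2(CO[C@@H]2O[C@@H]3CO[C@H](c4ccccc4)O[C@@H]3[C@H](OCc3ccccc3)[C@H]2OCc2ccccc2)c2ccccc2)cc1` was tested in a functional assay on A549 cells (Homo sapiens) for cytotoxicity, read by MTT assay, with a stated time of 48 h (on this read-out lower numbers stand for stronger inhibition and higher numbers for weaker inhibition), where compound 1 gives 599000 nM. Compound 2 `Cc1ccc(S(=O)(=O)N2C(C)C2CO[C@@H]2O[C@@H]3CO[C@H](c4ccccc4)O[C@@H]3[C@H](O)[C@H]2O)cc1` in this assay gives 351000 nM, and the two numbers lie within the usual scatter of each other, so neither can be called the stronger. Going by these compounds, compound 3 `Cc1ccc(S(=O)(=O)N2CC2(C)CO[C@@H]2O[C@@H]3CO[C@H](c4ccccc4)O[C@@H]3[C@H](OCc3ccccc3)[C@H]2OCc2ccccc2)cc1` is still untested; it differs from compound 1 by methyl in place of phenyl on a saturated ring carbon. Among the compounds with values here, no measured pair tells what such a swap does here, so compound 3 is expected to show no step beyond the scatter, a 1.2-fold lower number from compound 1 to compound 3 (0.08 log units; within the scatter). The estimate for compound 3 in this assay is 500000 nM, from 200000 nM to 1500000 nM.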

Compound 3, half-maximal inhibitory concentration: 153000 nM
Compound 3: the middle estimate sits 3.3-fold (0.51 log units) above what was measured; the measured number lies below the stated range.
By their numbers in this assay, from the lowest: compound 3; then compounds 2 and 1 (each within the scatter of the next).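

In this assay, methyl in place of phenyl on a saturated ring carbon of the three-membered non-aromatic ring gives a 3.9-fold lower number from compound 1 to compound 3 (0.59 log units; beyond the scatter) and so takes the number beyond the scatter. Within the data shown here, this is the first sign that the group on this carbon affects cytotoxicity, although the step is modest and rests on a single pair. No measurement shown gives a reason for the step. Going by these compounds, what an ethyl group, an amine or a carboxylic acid on this carbon would do remains open, as does whether the same swap would give a similar step on the core of compound 2.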